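Lengthening the amide chain on a shared core

The source may report more compounds than this note shows. Statements on the series, on what has been measured and on what is new or still open speak of the compounds shown alone.

Compound 1 `CNC(=O)c1cc(Oc2ccc(NC(=O)c3cc4cccnc4n(-c4ccc(OC)cc4)c3=O)cc2)ccn1` has no result in a functional assay on NCI-H460 cells (Homo sapiens) for antiproliferative activity, read by MTT assay, with a stated time of 72 h; a higher number here means a weaker inhibitor, a lower number a stronger inhibitor; for compound 1 the entry reads "not determined" (no result reported). Compound 2 `CNC(=O)c1cc(Oc2ccc(NC(=O)c3cc4cccnc4n(-c4ccc(C(F)(F)F)cc4Cl)c3=O)cc2)ccn1` gives 2110 nM in this assay, and that is the only number shown here, so it cannot be placed against any other measured compound. Compound 3 `CCCNC(=O)c1cc(Oc2ccc(NC(=O)c3cc4cccnc4n(-c4ccc(C(F)(F)F)cc4Cl)c3=O)cc2)ccn1` differs from compound 2 in a single place: ethyl in place of hydrogen on a saturated chain carbon bound to an amide-type nitrogen. Going by the values given here, with no step between measured compounds to draw on, the expected step of a 1.2-fold higher number from compound 2 to compound 3 (0.09 log units; within the scatter) is small, within the usual scatter, leaning if at all toward a weaker inhibitor. Compound 3 is therefore estimated at 2600 nM, with a range from 900 nM to 7500 nM.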

Compound 3, half-maximal inhibitory concentration: 3170 nM
Compound 3: the middle estimate sits 1.2-fold (0.09 log units) below what was measured, and the stated range covers the measured number.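

In this assay, lengthening methylcarbamoyl to propylcarbamoyl gives a 1.5-fold higher number from compound 2 to compound 3 (0.18 log units; within the scatter) on the shared core. Going by these compounds alone, this is the first reading of any change at this position, and it shows that adding ethyl to this chain carbon leaves compound 3 indistinguishable from compound 2 in this measurement. No supporting data bear on why this is so. Still open, from the compounds shown here alone, is whether a longer chain such as hexyl, a terminal amine or a carboxylic acid at the chain end would shift the number beyond the scatter.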